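This account rests on a few compounds, and the source may have more. Where it says the series, first, only, none or still open, it means among the compounds named here.

Measured compounds in a functional assay for agonist activity at growth hormone secretagogue receptor type 1 (Homo sapiens), read by FLIPR; on this read-out lower numbers stand for an effect already at smaller amounts and higher numbers for an effect only at larger amounts of compound:
- compound 1 `COc1ccc(N2C[C@@H](C)N[C@@H](C)C2)cc1NS(=O)(=O)c1ccc(-c2ccccc2)cc1` gives 6.31 nM
- compound 2 `COc1cccc(-c2ccc(S(=O)(=O)Nc3cc(N4C[C@@H](C)N[C@@H](C)C4)ccc3OC)cc2)c1` gives 2 nM
- compound 3 `COc1ccc(N2C[C@@H](C)N[C@@H](C)C2)cc1NS(=O)(=O)c1ccc(-n2cccn2)cc1` gives 15.9 nM

Compound 3 stands at the highest number of the three. Its nearest neighbour is compound 1, as the step of a 2.5-fold higher number from compound 1 to compound 3 (0.40 log units; beyond the scatter) shows, and its furthest is compound 2, with an 8.0-fold higher number from compound 2 to compound 3 (0.90 log units; beyond the scatter). Compound 4 `COc1ccc(N2C[C@@H](C)N[C@@H](C)C2)cc1NS(=O)(=O)c1ccc(-c2cccs2)cc1` differs from compound 3 in one place: thiophen-2-yl in place of 1H-pyrazol-1-yl on an aromatic carbon. Among the compounds with values here, two measured steps bear on this change. Going from phenyl to 1H-pyrazol-1-yl raised the number, a 2.5-fold higher number from compound 1 to compound 3 (0.40 log units; beyond the scatter), and going from 3-methoxyphenyl to 1H-pyrazol-1-yl raised it further, an 8.0-fold higher number from compound 2 to compound 3 (0.90 log units; beyond the scatter). Compound 4 goes the other way, exchanging a five-membered aromatic ring with two hetero atoms for one with a single hetero atom, so a modest step toward lower numbers in this assay is expected, roughly undoing the step seen in compound 1 against compound 3. Compound 4 is therefore estimated at 7 nM, with a range from 2.5 nM to 20 nM. For compound 4 this estimate means a 2.3-fold lower number from compound 3 to compound 4 (0.36 log units; beyond the scatter).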

Compound 4, half-maximal effective concentration: 3.98 nM
The estimate for compound 4 lay 1.8-fold (0.25 log units) above the measured number; the measured number falls inside the stated range.
By their numbers in this assay, from the lowest: compounds 2, 4 and 1 (each within the scatter of the next, the first and the last beyond it); then compound 3.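

In this assay, placing thiophen-2-yl instead of 1H-pyrazol-1-yl on this ring position, para to a large group, gives a 4.0-fold lower number from compound 3 to compound 4 (0.60 log units; beyond the scatter), so two five-membered aromatic rings with the same count of heavy atoms can still differ beyond the scatter. Thiophen-2-yl also cannot be told apart from the larger groups at this position, with a 1.6-fold lower number from compound 1 to compound 4 (0.20 log units; within the scatter) and a 2.0-fold higher number from compound 2 to compound 4 (0.30 log units; within the scatter) both within the scatter. No measured evidence is available on why the two five-membered rings differ.

As far as these compounds go, whether furan-2-yl, thiophen-3-yl or a carboxylic acid at this position would sit with thiophen-2-yl or with 1H-pyrazol-1-yl remains open. All four compounds share one core, and how these rings behave on a different core is also unsettled.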